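Swapping 4,4-difluorocyclohexyl for cyclohexyl in compound 3

This account rests on a few compounds, and the source may have more. Where it says the series, first, only, none or still open, it means among the compounds named here.

Measured in a physicochemical assay for solubility; on this read-out higher numbers stand for higher solubility and lower numbers for lower solubility:
- Compound 1 `O=C(NC1CCCCC1)c1cnc(-c2ccc(Cl)cc2)c(-c2ccc(Cl)cc2)n1`: < 100 nM (a limit, not a number)
- Compound 2 `COCc1nc(-c2ccc(Cl)cc2)c(-c2ccc(Cl)cc2)nc1C(=O)NC1CCC(F)(F)CC1`: < 100 nM (a limit, not a number)
- Compound 3 `FC1(F)CCC(NC(=S)c2cnc(-c3ccc(Cl)cc3)c(-c3ccc(Cl)cc3)n2)CC1`: 6600 nM

Among the compounds with values here, compound 3 holds the only actual number in this small set, while the other two entries are limits. Compound 4 `S=C(NC1CCCCC1)c1cnc(-c2ccc(Cl)cc2)c(-c2ccc(Cl)cc2)n1` has not yet been measured. It carries cyclohexyl in place of 4,4-difluorocyclohexyl on an amide-type nitrogen. Within the data shown here, no measured pair differs in just one place, so the size of this change in this assay has no direct guide. The expectation therefore starts from compound 3 at 6600 nM, with a modest fall expected, perhaps none beyond the scatter. The expected change is a 1.9-fold lower number from compound 3 to compound 4 (0.28 log units; within the scatter). Compound 4 is estimated at 3500 nM, with an expected range from 1000 nM to 10000 nM.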

Compound 4, solubility: 6100 nM
For compound 4 the middle estimate is 1.7-fold (0.24 log units) below the measured one; measured number inside the range.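

In this assay the cyclohexyl and 4,4-difluorocyclohexyl rings on the amide-type nitrogen read alike, with a 1.1-fold lower number from compound 3 to compound 4 (0.03 log units; within the scatter). The carbonyl of compound 1 and the thiocarbonyl of compound 4, by contrast, stand far apart, with an at least 61-fold higher number from compound 1 to compound 4 (1.78 log units; beyond the scatter). Compound 1 stands at a limit, not a number: the limit of < 100 nM in this assay, at which 2 of the 4 values shown sit.

Going by these compounds, whether a morpholine ring or a longer alkyl chain on this nitrogen would read like the two rings stays open. So does whether a thiocarbonyl in place of the carbonyl of compound 2 would give a similar step.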